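This account rests on a few compounds, and the source may have more. Where it says the series, first, only, none or still open, it means among the compounds named here.

Working notes on the series.

Compound 1 `O=C(Nc1ccccc1)Nc1ccc(Oc2ccc(-c3nccs3)cc2)cc1` carries an unsubstituted phenyl on the urea nitrogen. In a functional assay on MDA-MB-231 cells (Homo sapiens) for inhibition, read by MTT assay and WST assay, with a stated time of 72 h, tested at 10 uM (a lower number here means less inhibition of growth, a higher number more inhibition of growth at the concentration tested), compound 1 gives "not determined" (no result reported), so there is no number to place it on. Two substituted analogues have been measured. In this assay compound 2 `O=C(Nc1ccc(Oc2ccc(-c3nccs3)cc2)cc1)Nc1ccc(Cl)c([N+](=O)[O-])c1` gives 72.8%. In this assay compound 3 `O=C(Nc1ccc(Oc2ccc(-c3nccs3)cc2)cc1)Nc1ccc(F)c(C(F)(F)F)c1` gives 71.8%. Among the measured compounds shown here, the one measured step, a number 1 percentage points lower from compound 2 to compound 3 (within the scatter), shows that exchanging one substituted aryl for another on the urea nitrogen leaves the read-out unchanged within the scatter.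

Compound 4 `O=C(Nc1ccc(Oc2ccc(-c3nccs3)cc2)cc1)Nc1cc(C(F)(F)F)ccc1Cl` differs from compound 1 in one place: 2-chloro-5-(trifluoromethyl)phenyl in place of phenyl on an amide-type nitrogen. For the measured compounds named here, no measured step starts from a plain phenyl, so the size of this step cannot be read from the data; only the level reached by compounds 2 and 3 is known. Compound 4 is expected to land near that level, estimated at 70% with a range from 55% to 85%, because compound 2 gives 72.8% and compound 3 gives 71.8%.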

Compound 4, percent growth inhibition at one concentration: 60.4%
For compound 4 the middle estimate is 9.6 percentage points above the measured one; the measured number falls inside the stated range.
By their numbers in this assay, from the lowest: compound 4; then compounds 3 and 2 (each within the scatter of the next).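

Among the compounds shown here, compound 4 gives the first change at this position that lies beyond the scatter. The urea nitrogen had tolerated the exchange between compounds 2 and 3, but in this assay 2-chloro-5-(trifluoromethyl)phenyl gives a number 11.4 percentage points lower from compound 3 to compound 4 (beyond the scatter) and a number 12.4 percentage points lower from compound 2 to compound 4 (beyond the scatter) for the same position, so the read-out does depend on which substituted aryl sits there. Compounds 3 and 4 both carry trifluoromethyl, so the presence of that group alone does not hold the level seen for compound 3, and nothing on hand explains the drop.

From the compounds shown here alone, with no number for compound 1, the effect of any of these aryl groups against plain phenyl remains unknown. Also open, going by these compounds, is how an amine or a carboxylic acid on this aryl ring would read in this assay at this position.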